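Urea Analogues on a Shared Core: Estimating Compound 4

This account rests on a few compounds, and the source may have more. Where it says the series, first, only, none or still open, it means among the compounds named here.

Measured compounds:
- compound 1, `COc1cc(Cl)cc(-c2nn(-c3cccc(NC(=O)c4ccc(Cl)c(Cl)c4)c3)cc2-c2ccncc2)c1`, gives 34% in a functional assay on PC-3 cells (Homo sapiens) for inhibition, read by sulforhodamine B assay, with a stated time of 48 h, tested at 10 uM; on this read-out higher numbers stand for a weaker effect at the one concentration tested and lower numbers for a stronger effect
- compound 2, `COc1cc(Cl)cc(-c2nn(-c3cccc(NC(=O)Nc4ccc(Cl)c(C(F)(F)F)c4)c3)cc2-c2ccncc2)c1`, gives -13% in this assay
- compound 3, `COc1cc(Cl)cc(-c2nn(-c3cccc(NC(=O)Nc4ccc(Cl)c(Cl)c4)c3)cc2-c2ccncc2)c1`, gives -5.03% in this assay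

Compound 3 stands second highest of the three numbers. Its nearest neighbour is compound 2, and the two lie within the scatter of each other, so no order between them can be read. Compound 1, the amide rather than the urea, stands well apart: a number 39 percentage points lower from compound 1 to compound 3 (beyond the scatter), and likewise a number 47 percentage points lower from compound 1 to compound 2 (beyond the scatter).

Compound 4, `COc1cc(Cl)cc(-c2nn(-c3cccc(NC(=O)Nc4cccc(C(F)(F)F)c4)c3)cc2-c2ccncc2)c1`, has not been measured. It differs from compound 3 in one place: 3-(trifluoromethyl)phenyl in place of 3,4-dichlorophenyl on an amide-type nitrogen.

The step that bears on this change is a number 8 percentage points higher from compound 2 to compound 3 (within the scatter), which shows that exchanging chloro for trifluoromethyl on the aromatic ring made no difference beyond the scatter. Among the compounds with values here, the move to compound 4 also removes one chlorine from the ring, a change for which no measured pair exists. Since the urea compounds 2 and 3 sit close together, the expectation is a step within the scatter, perhaps slightly higher in this assay.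

Compound 4 is therefore estimated at 2%, with a range from -20% to 25%, meaning an expected step of a number 7 percentage points higher from compound 3 to compound 4 (within the scatter).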

Compound 4, a percentage reported as activity, at one concentration (the size of the read-out at that concentration, not a potency): -9.92%
For compound 4 the middle estimate is 11.9 percentage points above the measured one; low and high end bracket the measured number.
By their numbers in this assay, from the lowest: compounds 2, 4 and 3 (each within the scatter of the next); then compound 1.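

In this assay, the aromatic group on the urea's amide-type nitrogen can change more than the earlier pair of ureas showed: 3-(trifluoromethyl)phenyl in place of 3,4-dichlorophenyl gives a number 4.9 percentage points lower from compound 3 to compound 4 (within the scatter) and hydrogen in place of chloro gives a number 3.1 percentage points higher from compound 2 to compound 4 (within the scatter), so neither exchange moves the number beyond the usual scatter. The separation from the amide now holds for a third urea, one with no chloro on that ring, with a number 43.9 percentage points lower from compound 1 to compound 4 (beyond the scatter) as the step for (3-(trifluoromethyl)phenyl)amino in place of 3,4-dichlorophenyl on the carbonyl carbon. No independent measurement is available to explain why these ring changes leave the number within the scatter or why the amide stands apart.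

Still open, from the compounds shown here alone, is whether a plain phenyl on that nitrogen, or a ring carrying an amine or a carboxylic acid, would stay in the same range as the three ureas. Also open is how a thiourea or a sulfonamide would compare, since only the amide and the urea link appear among these compounds.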